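A few compounds are considered here, and "the series" means these few. Any claim that something is new, unique, unknown or untested is made for them only; others in the source may bear on it.

Two compounds anchor this comparison. Compound 1 `Cc1nc(C(F)(F)F)ccc1C(=O)Nc1ccc(Cl)c(-c2nc3ccccc3s2)c1` in an assay on C3H 10T1/2 cells for inhibition of Sonic hedgehog protein (Mus musculus), read by a luciferase reporter (a lower number here means a stronger inhibitor, a higher number a weaker inhibitor), gives 70 nM. Compound 2 `Cc1ccc(C(=O)Nc2ccc(Cl)c(-c3ccccn3)c2)c(C)n1` in this assay gives 130 nM. On the numbers shown, compound 2 is one of only two measured compounds, and its value and that of compound 1 lie within the usual scatter of each other, so the two cannot be told apart on these data. They differ from one another in several places at once, and no single step between them is shown.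

Compound 3 `O=C(Nc1ccc(Cl)c(-c2ccccn2)c1)c1cccc(Cl)c1` is not yet measured. It differs from compound 2 in one place: 3-chlorophenyl in place of 2,6-dimethylpyridin-3-yl on a carbonyl carbon. The rest of compound 2 is kept unchanged. Among the compounds with values here, since no measured step connects this change to a number, any expectation rests only on the values of compound 1 and compound 2, which both sit in a narrow band. The step from compound 2 to compound 3 is expected to be small to moderate and toward a higher number, a 1.9-fold higher number from compound 2 to compound 3 (0.28 log units; within the scatter). Compound 3 is therefore estimated at 250 nM in this assay, with a range from 80 nM to 800 nM.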

Compound 3, half-maximal inhibitory concentration: 1500 nM
For compound 3 the middle estimate is 6.0-fold (0.78 log units) below the measured one; measured number above the stated range.
By their numbers in this assay, from the lowest: compounds 1 and 2 (each within the scatter of the next); then compound 3.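

In this assay, 3-chlorophenyl in place of 2,6-dimethylpyridin-3-yl on a carbonyl carbon gives a 12-fold higher number from compound 2 to compound 3 (1.06 log units; beyond the scatter), a large step beyond the scatter. The earlier compounds shown here differed in several places at once and could not show this, but the step shows that, with the rest of compound 2 unchanged, the group on this carbonyl carbon strongly affects the number read in this assay. The change nevertheless has several parts: the ring hetero atom and the hydrogen-bond acceptor leave, the two methyl groups go, and a chlorine enters, and nothing measured here separates these parts or explains the rise in the number.

From the compounds shown here alone, what remains open is which part of the exchange carries the step, and a plain phenyl, a 3-methylphenyl or a pyridin-3-yl with a single methyl group on the same carbonyl carbon would begin to divide it. Going by these compounds, it is also open whether this group matters as much on the core of compound 1, or whether a 3-methoxyphenyl or a 3-aminophenyl at this position would behave like either of the two groups compared here.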